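Thiophene carboxamide series: urea-to-thiourea exchange on ring nitrogen

The compounds below may be only part of what the source reports. "The series", "measured", "known", "first", "only" and "open" are said of these compounds alone.

Compound 1 `NC(=O)c1c(NC(=O)c2ccccc2Cl)sc2c1CCN(Cc1ccc(Cl)cc1)C2` gives 22500 nM in a functional assay on HL-60 cells (Homo sapiens) for antiproliferative activity, with a stated time of 24 h (a higher number here means a weaker inhibitor, a lower number a stronger inhibitor), and compound 2 `NC(=O)c1c(NC(=O)c2ccccc2Cl)sc2c1CCN(C(=O)Nc1ccccc1Cl)C2` gives 12500 nM. The step of a 1.8-fold lower number from compound 1 to compound 2 (0.26 log units; within the scatter) is the only one measured so far. Among the compounds with values here, compound 2 therefore stands on one of two numbers, with compound 1 its sole neighbour, and the gap between them lies within the scatter, so neither can be called the stronger inhibitor.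

Compound 3 `COc1ccccc1NC(=S)N1CCc2c(sc(NC(=O)c3ccccc3Cl)c2C(N)=O)C1` differs from compound 2 by a group of 11 heavy atoms (8 carbon, 1 nitrogen, 1 oxygen, 1 sulfur; one six-membered aromatic ring of carbon only) in place of a group of 10 heavy atoms (7 carbon, 1 nitrogen, 1 oxygen, 1 chlorine; one six-membered aromatic ring of carbon only), on an amine nitrogen in a ring. Within the data shown here, no measured step exchanges a group of this kind; the single step recorded, a 1.8-fold lower number from compound 1 to compound 2 (0.26 log units; within the scatter), concerns a different replacement on the same nitrogen and was itself within the scatter. With nothing pointing either way, the step of no change at the digits printed from compound 2 to compound 3 (within the scatter) is expected to stay within the scatter. Compound 3 is estimated at 12500 nM, within 5000 nM to 32000 nM.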

Compound 3, half-maximal inhibitory concentration: 40900 nM
For compound 3 the middle estimate is 3.3-fold (0.51 log units) below the measured one, outside the stated range (above it).
By their numbers in this assay, from the lowest: compounds 2, 1 and 3 (each within the scatter of the next, the first and the last beyond it).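

Within the data shown here, at the amine nitrogen in a ring, this assay now gives the first step beyond the scatter, with a 3.3-fold higher number from compound 2 to compound 3 (0.51 log units; beyond the scatter) being modest in size; this exchange turns the carbonyl into a thiocarbonyl and replaces the chlorine on the aromatic ring with a methoxy group, so the step cannot be assigned to either alteration. Set against the 4-chlorobenzyl group, the same entering group gives a 1.8-fold higher number from compound 1 to compound 3 (0.26 log units; within the scatter) and stays within the scatter, so only compound 2 and compound 3 are separated at this position. Nothing available explains the step.

A thiourea carrying 2-chlorophenyl and a urea carrying 2-methoxyphenyl would separate the two alterations. Going by these compounds, how an acetyl group or a longer alkyl chain on the same nitrogen would compare also remains open.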